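The source may hold more compounds than are shown below. What is called first, only, known or untested is meant among the compounds shown, and "the series" means these compounds.

Compound 1 `CCSc1nnc(COc2cc(C)c3c(C)cc(=O)oc3c2)o1` — > 100000 nM
Compound 2 `Cc1cc(OCc2nnc(SCc3ccccc3)o2)cc2oc(=O)cc(C)c12` — > 100000 nM

In a functional assay on MCF7 cells (Homo sapiens) for antiproliferative activity, read by MTT assay, with a stated time of 24 h (on this read-out higher numbers stand for weaker inhibition and lower numbers for stronger inhibition), compound 1 gives > 100000 nM, which is a limit of the assay and not a number. In this assay compound 2 likewise gives > 100000 nM, again only a limit. For the measured compounds named here, the single measured step, a step that the two limits leave unreadable from compound 1 to compound 2, cannot be read in size because the limit of > 100000 nM in this assay, at which 2 of the 2 values shown sit, covers both values. Compound 2 therefore stands at the limit, with no number to place it against.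

Compound 3 is `CCCS(=O)(=O)c1nnc(COc2cc(C)c3c(C)cc(=O)oc3c2)o1`, which carries propylsulfonyl in place of benzylsulfanyl on an aromatic carbon. Going by the values given here, no measured step speaks to this change, and the one step that exists gives no readable size, so there is no basis for expecting a step in this assay in either direction. Compound 3 is accordingly estimated at 100000 nM, within a range from 30000 nM to 300000 nM, most probably reported as a limit. The step this expectation implies is a number no higher from compound 2 to compound 3 (the limit leaves the size open).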

Compound 3, half-maximal inhibitory concentration: > 100000 nM
Compound 3: no number, only a limit; the forecaster's own chance of this, stated with the estimate: 75%; the middle value sits exactly at the limit.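

In this assay compound 3 gives > 100000 nM, again a limit and not a number, so its steps from compound 1 and compound 2 cannot be read: the limit of > 100000 nM in this assay, at which 3 of the 3 values shown sit.

The compounds shown leave open whether ethylsulfanyl, benzylsulfanyl and propylsulfonyl differ at all in this assay.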